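Halogen swap on the sulfonyl ring, second instance

The source may report more compounds than this note shows. Statements on the series, on what has been measured and on what is new or still open speak of the compounds shown alone.

Three acylsulfonamides have so far been tested in a functional assay on B16-F10 cells (Mus musculus) for antiproliferative activity, read by ELISA and MTT assay, with a stated time of 48 h; on this read-out higher numbers stand for weaker inhibition and lower numbers for stronger inhibition. Compound 1 `O=C(/C=C/c1ccc(Cl)cc1)NS(=O)(=O)c1ccc(Cl)cc1` gives 2.5 ug/mL. Compound 2 `O=C(/C=C/c1ccc(Br)cc1)NS(=O)(=O)c1ccc(Cl)cc1` differs from compound 1 by bromo in place of chloro on an aromatic carbon. Compound 2 gives 5.2 ug/mL; the step of a 2.1-fold higher number from compound 1 to compound 2 (0.32 log units; beyond the scatter) is the only one among these compounds that reaches beyond the scatter. Compound 3 `CN(C)c1ccc(/C=C/C(=O)NS(=O)(=O)c2ccc(Cl)cc2)cc1` carries a different core, the difference from compound 1 being (dimethylamino in place of chloro on an aromatic carbon). Compound 3 gives 2.8 ug/mL; the step of a 1.1-fold higher number from compound 1 to compound 3 (0.05 log units; within the scatter) stays within the scatter, as does the step of a 1.9-fold lower number from compound 2 to compound 3 (0.27 log units; within the scatter), so no order can be drawn between compound 3 and either of its neighbours.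

Compound 4 `CN(C)c1ccc(/C=C/C(=O)NS(=O)(=O)c2ccc(Br)cc2)cc1` has not yet been measured in this assay. It differs from compound 3 by bromo in place of chloro on an aromatic carbon, which is the same change that turns compound 1 into compound 2, made at the same place on the ring; only the core around it differs, in the way already described for compound 3. Among the four compounds this change occurs twice, and only one instance carries a measurement.

Among the measured compounds shown here, for compound 4 the step of a 2.0-fold higher number from compound 3 to compound 4 (0.29 log units; within the scatter) is expected to resemble the earlier one, an expectation that rests on the single instance a 2.1-fold higher number from compound 1 to compound 2 (0.32 log units; beyond the scatter) and is therefore tentative. Compound 4 is accordingly estimated at 5.5 ug/mL, with a plausible range from 2.8 ug/mL to 10 ug/mL.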

Compound 4, half-maximal inhibitory concentration: 4.2 ug/mL
The estimate for compound 4 lay 1.3-fold (0.12 log units) above the measured number, and the stated range covers the measured number.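

In this assay, the change from 4-chlorophenyl to 4-bromophenyl gives a 1.5-fold higher number from compound 3 to compound 4 (0.18 log units; within the scatter), so this step on its own establishes no order between the two compounds. Set beside the earlier instance of the same change, the new step cannot be told apart from it: the same change on two cores in this assay, a 2.1-fold higher number (0.32 log units; beyond the scatter) from compound 1 to compound 2 and a 1.5-fold higher number (0.18 log units; within the scatter) from compound 3 to compound 4, 1.4-fold (0.14 log units) apart, within the scatter of two such steps. Among the compounds shown here, this agrees with the change carrying over from the core of compound 1 to the core of compound 3 without a detectable difference in step size, but it rests on only two pairs, one of them within the scatter, and it does not prove that the two steps are equal or that the change would behave alike on any other core.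

The compounds shown leave open how a fluoro group, a methoxy group or a carboxylic acid would read in place of the chloro or bromo on either core. As far as these compounds go, it also remains open whether the step would look the same on a core carrying a morpholine or a primary amine where compound 3 and compound 4 carry dimethylamino.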